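Removing the Amino and Nitro Groups: Compound 3 Forecast

This account rests on a few compounds, and the source may have more. Where it says the series, first, only, none or still open, it means among the compounds named here.

Compound 1 `COc1ccc(-c2c3ccc4ccccc4c3nc3c2c(C)nc2c4ccccc4ccc32)cc1` and compound 2 `Cc1nc2c3ccccc3ccc2c2nc3c(ccc4ccccc43)c(-c3cc([N+](=O)[O-])ccc3N)c12` share a large fused core and differ only in the ring attached to it. For the measured compounds named here, in a functional assay on AGS cells (Homo sapiens) for cytotoxicity, read by MTT assay, with a stated time of 48 h (on this read-out lower numbers stand for stronger inhibition and higher numbers for weaker inhibition), compound 1 gives 66400 nM, while compound 2 gives 17800 nM, the lower of the two numbers; the only measured step is a 3.7-fold lower number from compound 1 to compound 2 (0.57 log units; beyond the scatter). Compound 3 `Cc1nc2c3ccccc3ccc2c2nc3c(ccc4ccccc43)c(-c3ccccc3)c12` carries phenyl in place of 2-amino-5-nitrophenyl on an aromatic carbon. That lone step points the other way once the amino and nitro groups leave, so a modest return toward compound 1 is expected, namely a 2.2-fold higher number from compound 2 to compound 3 (0.35 log units; beyond the scatter). Compound 3 is therefore estimated at 40000 nM, within a range of 15000 nM to 110000 nM.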

Compound 3, half-maximal inhibitory concentration: > 80000 nM
Compound 3: only a limit was reported; the forecaster's own chance of this, stated with the estimate: 10%; middle value at least 2.0-fold (0.30 log units) away from the limit.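

In this assay compound 3 gives > 80000 nM, which is a limit and not a number. Replacing 2-amino-5-nitrophenyl with plain phenyl at this carbon, opposite the ring nitrogen, gives an at least 4.4-fold higher number from compound 2 to compound 3 (0.65 log units; beyond the scatter), so the lower number of compound 2 depends on the amino and nitro groups taken together. Replacing methoxy with hydrogen gives an at least 1.2-fold higher number from compound 1 to compound 3 (0.08 log units; that floor lies within the scatter), so no order can be set for that pair.

Which of the two groups accounts for the difference stays open. So does whether a hydroxyl or a carboxylic acid on the phenyl ring would also lower the number.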